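Methyl to methoxy on the amide-bearing ring: cytotoxicity note

The source may hold more compounds than are shown below. What is called first, only, known or untested is meant among the compounds shown, and "the series" means these compounds.

Measured so far:
- compound 1, `Cc1ccc(-c2nc3ccccc3o2)cc1NC(=O)c1cc([N+](=O)[O-])ccc1Cl`: > 14000 nM in an ADME assay on HEK293 cells (Homo sapiens) for cytotoxicity, with a stated time of 72 h; on this read-out lower numbers stand for an effect already at smaller amounts and higher numbers for an effect only at larger amounts of compound (a limit, not a number)
- compound 2, `O=C(Nc1nc(-c2cccc(F)c2)cs1)c1cc([N+](=O)[O-])ccc1Cl`: 8700 nM in this assay

Compound 1 carries a benzoxazolyl-substituted ring on the amide nitrogen and sits at the limit of this assay rather than at a measured number; of the two values shown, it is the one that is a limit (the limit of > 14000 nM in this assay, at which 1 of the 2 values shown sits). Compound 2, with a different ring on the amide nitrogen, gives a measured number in this assay of 8700 nM. Going by the values given here, no step between measured compounds is available, so the two values only show that compound 1 is the one without a number.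

The unmeasured compound 3, `COc1ccc(-c2nc3ccccc3o2)cc1NC(=O)c1cc([N+](=O)[O-])ccc1Cl`, keeps the core of compound 1 and changes a single group: methoxy in place of methyl on an aromatic carbon. The change is small in atom count and adds one hydrogen-bond acceptor.

Expected for compound 3: no step beyond the usual scatter, the estimated step being a number no higher from compound 1 to compound 3 (the limit leaves the size open). Compound 3 is therefore estimated at 14000 nM, with a range from 6000 nM to 40000 nM, and a good chance that this assay again reports only a limit.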

Compound 3, half-maximal effective concentration: > 25000 nM
Compound 3 ended at the assay's limit; the forecaster's own chance of this, stated with the estimate: 60%; middle value at least 1.7-fold (0.25 log units) away from the limit.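

Going by these compounds alone, compound 1 and compound 3 both sit at limits in this assay, not at numbers, so no step between them can be read. The compounds shown leave open what number either compound would reach, and so whether methoxy in place of methyl on an aromatic carbon shifts this read-out at all.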